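Swapping a pentan-3-yl sulfone for an oxetane sulfone

The compounds below may be only part of what the source reports. "The series", "measured", "known", "first", "only" and "open" are said of these compounds alone.

Compound 1 `CCC(CC)S(=O)(=O)c1ccc(S(=O)(=O)N2CCC[C@@H](C(=O)N3CCC(F)(F)CC3)C2)cc1` is the stronger of the two measured compounds. In a functional assay on BXPC-3 cells (Homo sapiens) for inhibition, read by MTT assay, with a stated time of 7 days (a higher number here means a weaker inhibitor, a lower number a stronger inhibitor), compound 1 gives 40 nM. Going by the values given here, the only other measured compound, compound 2 `CCN(CC)S(=O)(=O)c1ccc(S(=O)(=O)N2CCC[C@@H](C(=O)N3CCC(OC)CC3)C2)cc1`, gives 1420 nM in this assay, a weaker result that lies well beyond the usual scatter; compound 2 differs from compound 1 in more than one place, so its value says nothing on its own about any single change.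

Compound 3 `O=C([C@@H]1CCCN(S(=O)(=O)c2ccc(S(=O)(=O)C3COC3)cc2)C1)N1CCC(F)(F)CC1` is not yet measured. It differs from compound 1 in one place: oxetan-3-yl in place of pentan-3-yl on a sulfonyl sulfur. Among the compounds with values here, no measured pair shows this exact change, so no step can be read off for it. Compound 2, the only other point of reference, carries a different substituent on that same sulfonyl sulfur and a second change elsewhere, and its value in this assay is far weaker than that of compound 1.

For compound 3 a moderate loss is expected, and the step from a 6.3-fold higher number from compound 1 to compound 3 (0.80 log units; beyond the scatter) is estimated to fall outside the scatter. Compound 3 is therefore expected to give about 250 nM in this assay, with a plausible range from 60 nM to 1500 nM.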

Compound 3, half-maximal inhibitory concentration: 361 nM
For compound 3 the middle estimate is 1.4-fold (0.16 log units) below the measured one; low and high end bracket the measured number.
By their numbers in this assay, from the lowest: compound 1; then compound 3; then compound 2.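

Going by these compounds alone, this is the first change on this group that can be read on its own: with the rest of compound 1 untouched, oxetan-3-yl in place of pentan-3-yl on a sulfonyl sulfur gives a 9.0-fold higher number from compound 1 to compound 3 (0.96 log units; beyond the scatter) in this assay and so shows that the group at this place matters for the result. The swap costs strength without removing it, as compound 3 still gives 361 nM and remains a measurable inhibitor even though the open pentan-3-yl chain has given way to a four-membered ring that carries an oxygen. Nothing measured here accounts for the loss.

The swap alters three things at once, namely the presence of a ring, the presence of the oxygen and the number of heavy atoms, and the compounds shown cannot separate them. On these data alone, a cyclobutyl group on the same sulfonyl sulfur, a ring of carbon alone, would help to do so, and whether it would sit nearer to compound 1 or to compound 3 remains open, as does the effect of a longer chain at this place.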